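This account rests on a few compounds, and the source may have more. Where it says the series, first, only, none or still open, it means among the compounds named here.

Measured compounds:
- compound 1, `COc1cc(NC(C)CCCNC(=O)Nc2cccc(F)c2)c2ncccc2c1`: 18000 nM
- compound 2, `COc1cc(NC(C)CCCNC(=O)Nc2cccc(Cl)c2)c2ncccc2c1`: 11000 nM
- compound 3, `COc1cc(NC(C)CCCNC(=O)NNC(=O)Nc2ccc(Cl)cc2)c2ncccc2c1`: 180 nM

These three share a core and differ only in the group carried on the amide-type nitrogen. In a functional assay on MCF7 cells (Homo sapiens) for inhibition, read by MTT assay, with a stated time of 72 h (a higher number here means a weaker inhibitor, a lower number a stronger inhibitor), compound 1 gives the highest of the three numbers; its nearest neighbour is compound 2, at a 1.6-fold lower number from compound 1 to compound 2 (0.21 log units; within the scatter), and the furthest is compound 3, at a 100-fold lower number from compound 1 to compound 3 (2.00 log units; beyond the scatter). Compound 2 and compound 3 are separated by a 61-fold lower number from compound 2 to compound 3 (1.79 log units; beyond the scatter).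

The unmeasured compound 4, `COc1cc(NC(C)CCCNC(=O)NNC(=O)Nc2cccc(F)c2)c2ncccc2c1`, departs from compound 1 by one change: ((3-fluorophenyl)carbamoyl)amino in place of 3-fluorophenyl on an amide-type nitrogen

Among the measured compounds shown here, two measured steps bear on this change. The step from compound 1 to compound 3 combines the same insertion with a move from fluoro to chloro, whereas the step from compound 2 to compound 3 isolates the insertion against a chloro substituent; both are large and both point downward, and the halogen swap alone, from compound 1 to compound 2, stays within the scatter. A large downward step in this assay is therefore expected for compound 4, estimated at a 60-fold lower number from compound 1 to compound 4 (1.78 log units; beyond the scatter). Compound 4 is expected to give about 300 nM, within a range of 100 nM to 1000 nM.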

Compound 4, half-maximal inhibitory concentration: 150 nM
Estimate against measurement, compound 4: 2.0-fold (0.30 log units) above, and the stated range covers the measured number.
By their numbers in this assay, from the lowest: compounds 4 and 3 (each within the scatter of the next); then compounds 2 and 1 (each within the scatter of the next).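

In this assay, among the compounds shown here, a 120-fold lower number from compound 1 to compound 4 (2.08 log units; beyond the scatter) is the first step to carry the insertion with the 3-fluorophenyl ring left unchanged, so it reads the change on its own, with no swap of halogen or shift of its place on the ring. A further large step, a 73-fold lower number from compound 2 to compound 4 (1.87 log units; beyond the scatter), shows the same downward move from the chloro compound, which has a different halogen on the ring. With the longer group in place, the ring substitution makes no readable difference: a 1.2-fold lower number from compound 3 to compound 4 (0.08 log units; within the scatter) stays within the scatter, so 3-fluorophenyl and 4-chlorophenyl cannot be told apart here.

The compounds shown leave open whether an unsubstituted phenyl, or an amine or a carboxylic acid on that ring, would give a number like that of compound 4, and whether a longer chain in the shared core would do the same. Nothing measured here gives a reason for the large steps.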